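Warhead swap on the hydroxybenzoate series: sulfonamide to amide

The source may report more compounds than this note shows. Statements on the series, on what has been measured and on what is new or still open speak of the compounds shown alone.

Measured compounds in a functional assay on MV4-11 cells (Homo sapiens) for antiproliferative activity, read by luminescence, with a stated time of 72 h; a higher number here means a weaker inhibitor, a lower number a stronger inhibitor:
compound 1 `COc1cc(O)c(C(=O)OC(C)C)c(/C=C/CN2C(=O)C=CC2=O)c1`, 1730 nM
compound 2 `C/C=C/C(=O)NC/C=C/c1cc(OCCc2ccc(F)cc2)cc(O)c1C(=O)OC(C)C`, which reaches only a limit, > 10000 nM
compound 3 `C=CS(=O)(=O)NC/C=C/c1cc(OC)cc(O)c1C(=O)OC(C)C`, 4660 nM

Among the two numbers available, compound 3 stands highest; its nearest neighbour is compound 1, separated by a 2.7-fold higher number from compound 1 to compound 3 (0.43 log units; beyond the scatter). The value of compound 2 is a limit of the assay and not a number (the limit of > 10000 nM in this assay, at which 1 of the 3 values shown sits).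

Compound 4 `C/C=C/C(=O)NC/C=C/c1cc(OC)cc(O)c1C(=O)OC(C)C` is the next member. It differs from compound 3 in one place: (prop-1-en-1-yl)carbonyl in place of vinylsulfonyl on an amine nitrogen. Going by the values given here, no measured step covers exactly this exchange. Among the compounds with values here, the only step that bears on the region is the exchange at the saturated chain carbon from compound 1 to compound 3, which was modest. Compound 2 also carries the (prop-1-en-1-yl)carbonyl group on its amine nitrogen and gives only a limit, while its aryl ether differs from that of compound 4, so its value shows no more than that.

A modest step upward, or none beyond the scatter, is expected for a 1.4-fold higher number from compound 3 to compound 4 (0.14 log units; within the scatter). Compound 4 is therefore estimated at 6500 nM, within 2500 nM to 18000 nM.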

Compound 4, half-maximal inhibitory concentration: > 10000 nM
Compound 4: only a limit was reported; the forecaster's own chance of this, stated with the estimate: 30%; middle value at least 1.5-fold (0.18 log units) away from the limit.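

In this assay, going by these compounds alone, (prop-1-en-1-yl)carbonyl in place of vinylsulfonyl on the amine nitrogen gives an at least 2.1-fold higher number from compound 3 to compound 4 (0.33 log units; beyond the scatter) and so provides the first reading of this exchange. Against the ring-bearing group of compound 1, the same open-chain group gives an at least 5.7-fold higher number from compound 1 to compound 4 (0.76 log units; beyond the scatter) and places compound 4 behind both compound 1 and compound 3 on this core. Compound 4 and compound 2 each give a limit and not a number, so the step between them cannot be read and the aryl ether change remains unassessed: the limit of > 10000 nM in this assay, at which 2 of the 4 values shown sit.

As far as these compounds go, how far compound 4 lies beyond its limit remains open, so both readable steps have no upper size. Also open, from the compounds shown here alone, is whether a chloroacetyl or an unsubstituted acryloyl group on the amine nitrogen would give a number within the range of the assay.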